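This account rests on a few compounds, and the source may have more. Where it says the series, first, only, none or still open, it means among the compounds named here.

Compound 3 `COc1cccc(-c2ccc(C(=O)N(Cc3cccc(OCCCCCC(=O)O)c3)C(C)C)cc2)c1` is examined in an ADME assay on HEK293 cells (Homo sapiens) for cytotoxicity, read by CellTiter-Glo and resazurin assay, with a stated time of 72 h (on this read-out lower numbers stand for an effect already at smaller amounts and higher numbers for an effect only at larger amounts of compound), and gives only a limit there, > 20900 nM. Compound 1 `CC(C)N(Cc1cccc(OCCCCCC(=O)O)c1)C(=O)c1ccc(-c2cccc(Oc3ccccc3)c2)cc1` also gives only a limit in this assay, > 18700 nM. Compound 2 `CC(C)N(Cc1cccc(OCCCCCC(=O)O)c1)C(=O)c1ccc(-c2cccc(OCc3ccccc3)c2)cc1` gives only a limit too, > 26000 nM. The steps a step that the two limits leave unreadable from compound 1 to compound 2, a step that the two limits leave unreadable from compound 1 to compound 3 and a step that the two limits leave unreadable from compound 2 to compound 3 cannot be read; each end is a limit. Compound 4 `COc1ccc(F)c(-c2ccc(C(=O)N(Cc3cccc(OCCCCCC(=O)O)c3)C(C)C)cc2)c1` differs from compound 3 in one place: fluoro in place of hydrogen on an aromatic carbon. For the measured compounds named here, with no measured step readable, no direction and no size beyond the scatter can be drawn from them, and the expectation is that compound 4 again comes out as a limit in this assay. The step of an at least 1.0-fold lower number from compound 3 to compound 4 (0.01 log units; that floor lies within the scatter) that this estimate means is expected to be small. Compound 4 is estimated at 20000 nM, within a range from 10000 nM to 40000 nM.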

Compound 4, half-maximal effective concentration: > 26000 nM
Compound 4: a limit, no number (the forecaster's own chance of this, stated with the estimate: 85%); middle value at least 1.3-fold (0.11 log units) away from the limit.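

For the compounds shown here, compound 3 and compound 4 each give only a limit, so no step between them can be read. The compounds shown leave open at what amount any of them would affect these cells, and whether fluoro changes that amount.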